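Phenyl for methyl: a second instance on a related core

The source may report more compounds than this note shows. Statements on the series, on what has been measured and on what is new or still open speak of the compounds shown alone.

Compound 1 `Cc1cc2c(c(N)nn2C)c(=O)[nH]1` and compound 2 `Cn1nc(N)c2c(=O)[nH]c(-c3ccccc3)cc21` share a core, and compound 2 carries phenyl in place of methyl on an aromatic carbon. In an assay on isolated protein for inhibition of serine/threonine-protein kinase Chk2 (Homo sapiens), read by mobility shift assay, tested at 30 uM (on this read-out lower numbers stand for less inhibition and higher numbers for more inhibition at the one concentration tested (going by the name of the read-out)), compound 1 gives 3% and compound 2 gives 16%, the change making a number 13 percentage points higher from compound 1 to compound 2 (beyond the scatter). Compound 3 `COCCNc1nc(C)cc2c1c(N)nn2C` has a core whose difference from that of compound 1 is not broken down here; in this assay compound 3 gives -2%, the lowest of the three numbers, within the scatter of compound 1 and beyond it only against compound 2. Compound 4 `COCCNc1nc(-c2ccccc2)cc2c1c(N)nn2C`, not yet measured, repeats the same kind of change on the core of compound 3 (phenyl in place of methyl on an aromatic carbon). The surroundings differ in one respect: in compound 2 the phenyl stands meta to a group of 1 heavy atom, in compound 4 meta to a (2-methoxyethyl)amino group (5 heavy atoms); the rest reads the same. The step is expected at a number 13 percentage points higher from compound 3 to compound 4 (beyond the scatter), sized on the earlier instance because a number 13 percentage points higher from compound 1 to compound 2 (beyond the scatter) came from the same kind of change. For compound 4 the estimate in this assay is 11%, between -4% and 26%.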

Compound 4, a percentage reported as inhibition, at one concentration (the size of the read-out at that concentration, not a potency): 8%
Compound 4: middle estimate off by 3 percentage points, on the high side; measured number inside the range.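

In this assay, phenyl in place of methyl on an aromatic carbon gives a number 10 percentage points higher from compound 3 to compound 4 (within the scatter) on the core of compound 3. Set beside the earlier instance, the two steps do not differ, and the change carries over between these cores with a similar size: the same change on two cores in this assay, a number 13 percentage points higher (beyond the scatter) from compound 1 to compound 2 and a number 10 percentage points higher (within the scatter) from compound 3 to compound 4, 3 percentage points apart, within the scatter of two such steps. Among the compounds shown here, this does not show that phenyl reliably raises inhibition across the series, since the evidence is only two pairs, the step on the core of compound 3 does not by itself clear the scatter, and each figure is a reading at one concentration rather than a potency.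

The compounds shown leave open whether the same carry-over holds on a third core, or with the (2-methoxyethyl)amino group exchanged for a plain amine or a longer chain. They also leave open how a carboxylic acid, a cyclohexyl group or a phenyl bearing a fluorine would read on that aromatic carbon.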